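Trading 4-chlorophenyl for ethyl on a carbonyl carbon

This account rests on a few compounds, and the source may have more. Where it says the series, first, only, none or still open, it means among the compounds named here.

- compound 1 (`CC(=O)N1c2ccccc2CCC1C(=O)Nc1cc(C(F)(F)F)cc(C(F)(F)F)c1`): > 70000 nM (a limit)
- compound 2 (`O=C(Nc1cc(C(F)(F)F)cc(C(F)(F)F)c1)C1CCc2ccccc2N1C(=O)c1ccc(Cl)cc1`): 2220 nM

Among the compounds with values here, in a functional assay on HCT-15 cells (Homo sapiens) for cytotoxicity, read by sulforhodamine B assay, with a stated time of 72 h (on this read-out higher numbers stand for weaker inhibition of growth and lower numbers for stronger inhibition of growth), compound 2 gives 2220 nM, the only actual number so far. Compound 3 (`CCC(=O)N1c2ccccc2CCC1C(=O)Nc1cc(C(F)(F)F)cc(C(F)(F)F)c1`) carries ethyl in place of 4-chlorophenyl on a carbonyl carbon. Within the data shown here, the one measured step bearing on this is an at least 31-fold lower number from compound 1 to compound 2 (1.49 log units; beyond the scatter), where 4-chlorophenyl replaced methyl. Its starting point is a limit (the limit of > 70000 nM in this assay, at which 1 of the 2 values shown sits). Ethyl, like methyl, has no ring, so that step an at least 31-fold lower number from compound 1 to compound 2 (1.49 log units; beyond the scatter) is expected to run largely in reverse, giving a large move to a higher number in this assay. The expected change is a 20-fold higher number from compound 2 to compound 3 (1.31 log units; beyond the scatter). The estimate for compound 3 is 45000 nM, within 15000 nM to 90000 nM.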

Compound 3, concentration for 50% growth inhibition: 7620 nM
Beside the measured number, compound 3's estimate is 5.9-fold (0.77 log units) above it; the measured number lies below the stated range.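

In this assay, the ring of 4-chlorophenyl accounts for only part of the gain seen with compound 2, since ethyl loses just a modest amount: a 3.4-fold higher number from compound 2 to compound 3 (0.54 log units; beyond the scatter). Even the small change of methyl in place of hydrogen on the saturated chain carbon matters, giving an at least 9.1-fold lower number from compound 1 to compound 3 (0.96 log units; beyond the scatter). On these data alone, the true size of that step stays unknown because the value for compound 1 is a limit: the limit of > 70000 nM in this assay, at which 1 of the 3 values shown sits.

As far as these compounds go, whether a longer chain such as butanoyl would close the remaining gap stays open. So does how much of that gap belongs to the chlorine, which plain phenyl would show.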